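The source may report more compounds than this note shows. Statements on the series, on what has been measured and on what is new or still open speak of the compounds shown alone.

Three compounds share one core and differ only in the groups on two of its nitrogens: compound 1 `OC[C@H]1O[C@@H](n2cnc3c(NC4CCCC4)nc(NC4CC4)nc32)[C@H](O)[C@@H]1O`, compound 2 `OC[C@H]1O[C@@H](n2cnc3c(NC4CCCCC4)nc(NC4CCCC4)nc32)[C@H](O)[C@@H]1O` and compound 3 `OC[C@H]1O[C@@H](n2cnc3c(NC4CCCC4)nc(NC4CCCCC4)nc32)[C@H](O)[C@@H]1O`. All three were tested in an ADME assay on HEK-293T cells (Homo sapiens) for cytotoxicity, read by resazurin assay, with a stated time of 16 h; a higher number here means a weaker inhibitor, a lower number a stronger inhibitor. Compound 1 gives > 500000 nM, which is a limit of the assay and not a number. Compound 2 gives > 500000 nM, which is also a limit. Compound 3 gives an actual number, 228000 nM. Compound 2 is therefore a starting point with no exact value.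

Compound 4 `OC[C@H]1O[C@@H](n2cnc3c(NC4CCCCCC4)nc(NC4CCCC4)nc32)[C@H](O)[C@@H]1O` has not been measured yet. Its difference from compound 2 is small, with cycloheptyl in place of cyclohexyl on a nitrogen on an aromatic ring.

Going by the values given here, only one measured step bears on this change. Going to a larger ring on such a nitrogen, cyclohexyl in place of cyclopropyl, gives an at least 2.1-fold lower number from compound 1 to compound 3 (0.34 log units; beyond the scatter). The change to compound 4 is a smaller swap of ring, so a smaller move in the same direction is expected, and it may not clear the scatter. The expected move is an at least 1.6-fold lower number from compound 2 to compound 4 (0.22 log units; that floor lies within the scatter). A reading for compound 4 could also be expected to stay at the limit of > 500000 nM in this assay, at which 2 of the 3 values shown sit. For compound 4 the estimated value is 300000 nM, with an expected range from 120000 nM to 600000 nM.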

Compound 4, half-maximal inhibitory concentration: > 500000 nM
Compound 4: a limit, no number; the forecaster's own chance of this, stated with the estimate: 50%; at least 1.6-fold (0.22 log units) between middle value and limit.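

Compound 2 and compound 4 each give a limit and not an exact number, so no step can be read from compound 2 to compound 4, and both sit at the same ceiling: the limit of > 500000 nM in this assay, at which 3 of the 4 values shown sit.

The compounds shown leave open whether cycloheptyl in place of cyclohexyl on a nitrogen on an aromatic ring changes the reading at all, and in which direction.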